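The compounds below may be only part of what the source reports. "The series", "measured", "known", "first", "only" and "open" are said of these compounds alone.

The measured compounds in a functional assay on DU-145 cells (Homo sapiens) for antiproliferative activity, read by MTT assay, with a stated time of 72 h; a higher number here means a weaker inhibitor, a lower number a stronger inhibitor:
Compound 1 `O=C(COc1ccc(C(=O)/C=C/c2cccc(Cl)c2)cc1)N[C@H]1CCOC1=O` gives 3700 nM.
Compound 2 `O=C1OCC[C@@H]1NC(=S)SCCOc1ccc([N+](=O)[O-])cc1` gives 31000 nM.
Compound 3 `O=C(COc1ccc(C(=O)/C=C/c2ccc(F)cc2)cc1)N[C@H]1CCOC1=O` gives 18800 nM.

Compound 3 has the second highest number of the three; compound 2 sits within the scatter of it, while compound 1 is clearly lower. Compound 4 `O=C(COc1ccc(C(=O)/C=C/c2cccc([N+](=O)[O-])c2)cc1)N[C@H]1CCOC1=O` differs from compound 3 in one place: 3-nitrophenyl in place of 4-fluorophenyl on a double-bonded chain carbon bound to a double-bonded chain carbon. Among the measured compounds shown here, no measured step covers this exact exchange. For the measured compounds named here, the only step at the same place is a 5.1-fold higher number from compound 1 to compound 3 (0.71 log units; beyond the scatter), in which 3-chlorophenyl gave the lower number and 4-fluorophenyl the higher. Since compound 4 returns to a 3-substituted ring, as compound 1 does with 3700 nM, a modest move back toward lower numbers is expected, a 3.1-fold lower number from compound 3 to compound 4 (0.50 log units; beyond the scatter). Compound 4 is therefore estimated at 6000 nM, within 2000 nM to 20000 nM.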

Compound 4, half-maximal inhibitory concentration: 41800 nM
For compound 4 the middle estimate is 7.0-fold (0.84 log units) below the measured one, outside the stated range (above it).
By their numbers in this assay, from the lowest: compound 1; then compounds 3, 2 and 4 (each within the scatter of the next, the first and the last beyond it).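

In this assay, a 3-substituted ring alone does not secure a low number: an 11-fold higher number from compound 1 to compound 4 (1.05 log units; beyond the scatter), with 3-chlorophenyl and 3-nitrophenyl as the only difference. The group on the ring therefore matters here, and 3-nitrophenyl also fares worse than 4-fluorophenyl, with a 2.2-fold higher number from compound 3 to compound 4 (0.35 log units; beyond the scatter) as the step. Nothing available explains these differences.

Going by these compounds, whether 3-aminophenyl would fall nearer compound 1 or compound 4 remains open. So does the result for 4-chlorophenyl, which would separate the choice of group from its place on the ring.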